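This account rests on a few compounds, and the source may have more. Where it says the series, first, only, none or still open, it means among the compounds named here.

Measured so far in an assay on SH-EP1 cells for agonist activity at Neuronal acetylcholine receptor; alpha4/beta2 (Homo sapiens), read by FLIPR and calcium flux; a lower number here means that less compound is needed, a higher number that more compound is needed for the effect:
compound 1 `CC(=O)N1CC2CC(C1)N2`, 5100 nM
compound 2 `CCCC(=O)N1CC2CC(C1)N2`, 580 nM
compound 3 `O=C([C@H]1C[C@H]1F)N1CC2CC(C1)N2`, 210 nM

Compound 3 stands lowest of the three numbers; the nearest is compound 2, a 2.8-fold lower number from compound 2 to compound 3 (0.44 log units; beyond the scatter), the furthest compound 1, a 24-fold lower number from compound 1 to compound 3 (1.39 log units; beyond the scatter). Compound 4 `O=C([C@@H]1C[C@@H]1F)N1CC2CC(C1)N2` keeps the shared core and the 2-fluorocyclopropyl group on the carbonyl carbon; the change is the two compounds have the same atoms and bonds; at least one stereo element is drawn with a configuration in one of them and without one in the other: 2 of 4 stereo elements differ; a stereocentre at a saturated ring carbon is drawn R in compound 3 and S in compound 4; a stereocentre at a saturated ring carbon is drawn R in compound 3 and S in compound 4. Going by the values given here, none of the measured steps bears on this: an 8.8-fold lower number from compound 1 to compound 2 (0.94 log units; beyond the scatter), a 24-fold lower number from compound 1 to compound 3 (1.39 log units; beyond the scatter) and a 2.8-fold lower number from compound 2 to compound 3 (0.44 log units; beyond the scatter) all alter the group on the carbonyl carbon and say nothing about the drawn configuration. The direction of such a change is not fixed by these data, so the expected step is a 2.1-fold higher number from compound 3 to compound 4 (0.33 log units; beyond the scatter), with a wide range. For compound 4 the estimate is 450 nM, between 100 nM and 2500 nM.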

Compound 4, half-maximal effective concentration: 120 nM
Compound 4: middle estimate off by 3.8-fold (0.57 log units), on the high side; low and high end bracket the measured number.
By their numbers in this assay, from the lowest: compounds 4 and 3 (each within the scatter of the next); then compound 2; then compound 1.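

Reversing the drawn configuration at both ring carbons of the 2-fluorocyclopropyl group gives only a small step (a 1.8-fold lower number from compound 3 to compound 4 (0.24 log units; within the scatter)), so this position does not separate the two drawn forms. The 2-fluorocyclopropyl group in compound 4 also stands clear of propyl (a 4.8-fold lower number from compound 2 to compound 4 (0.68 log units; beyond the scatter)) and methyl (a 43-fold lower number from compound 1 to compound 4 (1.63 log units; beyond the scatter)). One caveat applies to reading the pair: the fact that one of compounds 3 and 4 is drawn with a defined configuration and the other without, at the place where they differ.

Open, as far as these compounds go, is whether plain cyclopropyl on the carbonyl carbon would read like the 2-fluorocyclopropyl group. Also open, from the compounds shown here alone, is whether an amine or a hydroxyl in place of the fluorine would hold the number.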